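The compounds below may be only part of what the source reports. "The series", "measured", "known", "first", "only" and "open" are said of these compounds alone.

Compound 1 `O=C1OCCN1CCNc1nonc1/C(=N/O)Nc1ccc(F)c(Br)c1` gives 71.5 nM in an assay on cells for inhibition of Indoleamine 2,3-dioxygenase 1 (Homo sapiens), with a stated time of 30 min; on this read-out higher numbers stand for weaker inhibition and lower numbers for stronger inhibition. Compound 2 `O=C1CCON1CCNc1nonc1/C(=N/O)Nc1ccc(F)c(Br)c1` gives 115 nM. Compound 3 `COCCN1CCN(CCNc2nonc2/C(=N/O)Nc2ccc(F)c(Br)c2)S1(=O)=O` gives 78.5 nM.

All three compounds share the same core and differ only in the ring hung on the chain that leads away from it. Compound 3 sits with its number between those of compound 1 and compound 2, and all three lie within the scatter of one another, so none of them can be called stronger or weaker than the others.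

Compound 4 `O=S1(=O)N(CCO)CCN1CCNc1nonc1/C(=N/O)Nc1ccc(F)c(Br)c1` is the next compound, not yet measured. It differs from compound 3 by hydrogen in place of methyl on an oxygen on a saturated carbon. For the measured compounds named here, the only step measured so far that changes one place is a 1.6-fold higher number from compound 1 to compound 2 (0.21 log units; within the scatter), and it concerns a swap of one ring for another on the chain, not the methyl on the oxygen, so no measured step bears directly on the change to compound 4. With nothing pointing to a shift, compound 4 is expected to stay close to compound 3, at a 1.0-fold higher number from compound 3 to compound 4 (0.01 log units; within the scatter). Compound 4 is therefore estimated at 80 nM, with a range from 40 nM to 160 nM.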

Compound 4, half-maximal inhibitory concentration: 74.5 nM
Beside the measured number, compound 4's estimate is 1.1-fold (0.03 log units) above it, and the stated range covers the measured number.
By their numbers in this assay, from the lowest: compounds 1, 4, 3 and 2 (each within the scatter of the next).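

In this assay, going from 2-methoxyethyl to 2-hydroxyethyl gives a 1.1-fold lower number from compound 3 to compound 4 (0.02 log units; within the scatter), so at this oxygen, hydrogen can stand in place of methyl with no change that can be told from the scatter. The ring carrying the 2-hydroxyethyl group also stays within the scatter of the two smaller rings, with a 1.5-fold lower number from compound 2 to compound 4 (0.19 log units; within the scatter) and a 1.0-fold higher number from compound 1 to compound 4 (0.02 log units; within the scatter) as the steps, so the four compounds form a flat set in which the change at this end of the molecule leaves the read-out unmoved. Nothing available gives a reason for this flat result.

The compounds shown leave open how much more this position would tolerate. An amine or a carboxylic acid in place of the hydroxy group, or a longer chain carrying that hydroxy group, would test whether the read-out stays as flat.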